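The source may hold more compounds than are shown below. What is called first, only, known or untested is meant among the compounds shown, and "the series" means these compounds.

Values so far in a physicochemical assay for lipophilicity; on this read-out lower numbers stand for lower lipophilicity and higher numbers for higher lipophilicity:
Compound 1 `C[C@H]1CC[C@@H]2[C@@H](OC(=O)[C@]23CC(c2ccccc2)=NO3)[C@]2(C)C(=O)C=C[C@@]12O` gives 1.41
Compound 2 `C[C@H]1CC[C@@H]2[C@@H](OC(=O)[C@]23CC(c2ccccc2F)=NO3)[C@]2(C)C(=O)C=C[C@@]12O` gives 1.58
Compound 3 `Cc1ccc(C2=NO[C@]3(C2)C(=O)O[C@@H]2[C@H]3CC[C@H](C)[C@]3(O)C=CC(=O)[C@@]23C)cc1` gives 1.86

All three compounds share one core and differ only in the aromatic ring attached to it. Within the data shown here, compound 3 reads 1.86 in this assay and stands well clear of only one neighbour. The widest gap is a number 0.45 log units higher from compound 1 to compound 3 (beyond the scatter), while the nearest neighbour gives a number 0.28 log units higher from compound 2 to compound 3 (within the scatter).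

Compound 4 `C[C@H]1CC[C@@H]2[C@@H](OC(=O)[C@]23CC(c2ccc(C#N)cc2)=NO3)[C@]2(C)C(=O)C=C[C@@]12O` keeps the core of compound 3 and has cyano in place of methyl on an aromatic carbon, para to a large group (cyano in place of methyl on an aromatic carbon). This removes the methyl, so the most relevant measurement is the step that added it: a number 0.45 log units higher from compound 1 to compound 3 (beyond the scatter). Simply reversing that step would bring the number back towards that of compound 1 (1.41). The only other substitution on the same parent is a number 0.17 log units higher from compound 1 to compound 2 (within the scatter), which says little here. Among the measured compounds shown here, no measured compound carries a cyano, so its own contribution remains unknown and the range must stay wide.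

A step towards lower numbers is expected, somewhat larger than the methyl step: a number 0.66 log units lower from compound 3 to compound 4 (beyond the scatter). For compound 4 the estimated value is 1.2, with an expected range from 0.8 to 1.6.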

Compound 4, partition coefficient: 1.17
Beside the measured number, compound 4's estimate is 0.03 log units above it; measured number inside the range.
By their numbers in this assay, from the lowest: compounds 4, 1, 2 and 3 (each within the scatter of the next, the first and the last beyond it).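

In this assay, the place para to a large group on the aromatic ring has now carried hydrogen, methyl and cyano, and the swap of methyl for cyano gives a number 0.69 log units lower from compound 3 to compound 4 (beyond the scatter) as the largest step in the set so far, showing that a single group at this place can move the reading beyond the scatter. Cyano in place of hydrogen gives a number 0.24 log units lower from compound 1 to compound 4 (within the scatter) and so stays within the scatter, which means compound 4 cannot be told apart from compound 1 and the methyl-to-cyano step is about the size of what the methyl had added on its own. The swap of 2-fluorophenyl for 4-cyanophenyl gives a number 0.41 log units lower from compound 2 to compound 4 (beyond the scatter) as a further step beyond the scatter, although it changes both the group and its place on the ring, so it says less about this one position.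

On these data alone, how an amine, a carboxylic acid or a longer chain at this place would read remains open, as does whether cyano elsewhere on the ring would match compound 4. Nothing available here explains why these groups give the readings they do.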